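Swapping the amide side chain of compound 1 for a carboxymethyl group

This account rests on a few compounds, and the source may have more. Where it says the series, first, only, none or still open, it means among the compounds named here.

Three close relatives sharing one core have been tested in a functional assay on PC-3 cells (Homo sapiens), read by MTT assay, with a stated time of 48 h; on this read-out lower numbers stand for stronger inhibition and higher numbers for weaker inhibition. Compound 1 `CCN(CC)CCNC(=O)c1ccc(C(CC)(CC)c2ccc(OCC(O)C(C)(C)C)c(C)c2)n1CC` gives 220 nM, the lowest number of the three and therefore the strongest inhibitor in this set. Compound 2 `CCn1c(C(=O)NCCCN(C)C)ccc1C(CC)(CC)c1ccc(OCC(O)C(C)(C)C)c(C)c1` gives 3100 nM, and compound 3 `C#CCNC(=O)c1ccc(C(CC)(CC)c2ccc(OCC(O)C(C)(C)C)c(C)c2)n1CC` gives 16200 nM.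

Compound 4 `CCn1c(C(=O)N(C)CC(=O)O)ccc1C(CC)(CC)c1ccc(OCC(O)C(C)(C)C)c(C)c1` has not yet been measured. Its change from compound 1 is (carboxymethyl)(methyl)amino in place of (2-(diethylamino)ethyl)amino on a carbonyl carbon. The amide thus loses the (2-(diethylamino)ethyl)amino chain and gains a (carboxymethyl)(methyl)amino group.

Two measured steps speak to this. Shrinking the amine end gave a 14-fold higher number from compound 1 to compound 2 (1.15 log units; beyond the scatter), and removing the amine-bearing chain altogether gave a 74-fold higher number from compound 1 to compound 3 (1.87 log units; beyond the scatter). Compound 4 likewise carries no amine on the side chain, so a large loss is expected, estimated as a 68-fold higher number from compound 1 to compound 4 (1.83 log units; beyond the scatter) in this assay. For compound 4 the estimate in this assay is 15000 nM, with a likely range from 4000 nM to 60000 nM.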

Compound 4, half-maximal inhibitory concentration: 23900 nM
Estimate against measurement, compound 4: 1.6-fold (0.20 log units) below; low and high end bracket the measured number.
By their numbers in this assay, from the lowest: compound 1; then compound 2; then compounds 3 and 4 (each within the scatter of the next).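

In this assay, putting (carboxymethyl)(methyl)amino on the carbonyl carbon in place of (2-(diethylamino)ethyl)amino gives a 110-fold higher number from compound 1 to compound 4 (2.04 log units; beyond the scatter), and the change from the shorter amine end gives a 7.7-fold higher number from compound 2 to compound 4 (0.89 log units; beyond the scatter). Compound 4 is not separated from compound 3, at a 1.5-fold higher number from compound 3 to compound 4 (0.17 log units; within the scatter), so a side chain ending in a carboxylic acid and one ending in an alkyne read alike here, and among these four compounds only compounds 1 and 2, which carry a side-chain amine, give the lower numbers. Nothing measured here gives a reason for these steps.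

Compound 4 also gains a methyl on the amide nitrogen, so a carboxymethylamino amide without that methyl, or the methyl ester of the acid, would be needed to tell the two changes apart. Compounds 1 and 2 differ in both chain length and amine end, so a longer chain ending in diethylamino remains an open case.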